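Quinazoline thioacetamide anilides: bromophenyl to chloro-fluorophenyl swap

The compounds below may be only part of what the source reports. "The series", "measured", "known", "first", "only" and "open" are said of these compounds alone.

Measured so far
compound 1, `COc1cccc(NC(=O)CSc2nc(Nc3ccccc3)c3ccccc3n2)c1`: 19400 nM
compound 2, `C=CC(=O)Nc1cccc(NC(=O)CSc2nc(Nc3cccc(Br)c3)c3ccccc3n2)c1`: 12100 nM

Two compounds of the shared core have numbers in a functional assay on NCI-H1975 cells (Homo sapiens) for inhibition, read by MTT assay, with a stated time of 72 h; on this read-out lower numbers stand for stronger inhibition and higher numbers for weaker inhibition. Compound 1, with its structure `COc1cccc(NC(=O)CSc2nc(Nc3ccccc3)c3ccccc3n2)c1`, gives 19400 nM. Compound 2, with its structure `C=CC(=O)Nc1cccc(NC(=O)CSc2nc(Nc3cccc(Br)c3)c3ccccc3n2)c1`, gives 12100 nM. Compound 2 has the lower of the two numbers, but its distance to compound 1 lies within the scatter, so the two cannot be told apart on what is known; compound 2 differs from compound 1 in more than one place, so no single step can be read from this pair.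

Compound 3, `C=CC(=O)Nc1cccc(NC(=O)CSc2nc(Nc3ccc(F)c(Cl)c3)c3ccccc3n2)c1`, is not yet measured. It differs from compound 2 in one place: 3-chloro-4-fluorophenyl in place of 3-bromophenyl on a nitrogen on an aromatic ring. For the measured compounds named here, no measured pair shows what such a change does. With nothing to lean on, the step from compound 2 to compound 3 is expected to be a 1.0-fold lower number from compound 2 to compound 3 (0.00 log units; within the scatter), that is, no change beyond the scatter in either direction. Compound 3 is therefore estimated at 12000 nM, with a range from 4500 nM to 32000 nM.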

Compound 3, half-maximal inhibitory concentration: > 50000 nM
Compound 3: only a limit was reported; the forecaster's own chance of this, stated with the estimate: 5%; middle value at least 4.1-fold (0.61 log units) from the limit.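

In this assay, the aryl group on a nitrogen on an aromatic ring proves to be a place where the read-out responds, with 3-chloro-4-fluorophenyl in place of 3-bromophenyl giving an at least 4.1-fold higher number from compound 2 to compound 3 (0.61 log units; beyond the scatter). Compound 3 gives > 50000 nM, which is a limit of the assay and not a number. This is the first single-place step in the series, since compound 1 and compound 2 differ in more than one place and stand within the scatter of each other, and its full size stays unknown, as it rests on a limit: the limit of > 50000 nM in this assay, at which 1 of the 3 values shown sits.

The compounds shown do not separate the part played by the chlorine from that played by the fluorine, nor show whether the step would hold with a single halogen on this phenyl ring. As far as these compounds go, how a methoxy group, a nitrile or a morpholine on the same ring would read, and whether any group here gives a number clearly lower than that of compound 2, also remains open.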